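This account rests on a few compounds, and the source may have more. Where it says the series, first, only, none or still open, it means among the compounds named here.

Three close relatives of one purine-like core have been tested for cytotoxicity, and all three returned only a limit. Compound 1, `COc1cccc(CNc2ncnc3c2ncn3C2CCCCO2)c1O`, carries a methoxy and a hydroxy on its benzyl ring. In an ADME assay on K562 cells (Homo sapiens) for cytotoxicity, with a stated time of 72 h (on this read-out lower numbers stand for stronger inhibition and higher numbers for weaker inhibition), compound 1 gives > 100000 nM, which is a limit of the measurement rather than a number. Compound 2, `COc1cc(CNc2ncnc3c2ncn3C2CCCCO2)ccc1O`, is the same kind of molecule with its two oxygen substituents placed differently. In this assay compound 2 gives > 100000 nM, again a limit. Compound 3, `COc1ccc(CNc2ncnc3c2ncn3C2CCCCO2)cc1OC`, keeps both oxygens methylated. In this assay compound 3 gives > 100000 nM, once more a limit. The change from compound 3 to compound 2 is hydrogen in place of methyl on an oxygen on an aromatic ring, and the corresponding step, a step that the two limits leave unreadable from compound 3 to compound 2, cannot be sized since both ends sit at the limit. The difference between the cores of compound 1 and compound 3 is not broken down here.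

Compound 4, `Oc1cccc(CNc2ncnc3c2ncn3C2CCCCO2)c1O`, has not yet been measured. It differs from compound 1 by hydrogen in place of methyl on an oxygen on an aromatic ring, the same change that separates compound 3 from compound 2. For compound 4 the step from compound 1 is expected to be a step that the limit leaves unreadable from compound 1 to compound 4, placed beside the unreadable earlier step, and this expectation rests on (the limit of > 100000 nM in this assay, at which 3 of the 3 values shown sit), since every measured relative has already stopped at that boundary. Compound 4 is therefore estimated at 150000 nM, with a range from 60000 nM to 400000 nM, most probably reported as a limit as well.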

Compound 4, half-maximal inhibitory concentration: 92000 nM
For compound 4 the middle estimate is 1.6-fold (0.21 log units) above the measured one; measured number inside the range.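

In this assay, hydrogen in place of methyl on an oxygen on an aromatic ring gives an at least 1.0-fold lower number from compound 1 to compound 4 (0.03 log units; that floor lies within the scatter); since compound 1 stands only at a limit, this is a floor and establishes neither a real change nor its size. The same change from compound 3 to compound 2 cannot be read, so the two steps cannot be set against each other, and nothing here shows whether the change carries from one core to the other. The one thing the series does show is that compound 4 alone returns a number, 92000 nM. The other three compounds return only a limit, which is what leaves the comparison without a size: the limit of > 100000 nM in this assay, at which 3 of the 4 values shown sit.

The compounds shown vary only methoxy and hydroxy groups on the benzyl ring, which leaves open whether an amine or a carboxylic acid on that ring would bring the read-out in this assay clear of the limit. Also open, from the compounds shown here alone, are the effect of a longer chain linking the benzyl ring to the shared core, and whether the step from methoxy to hydroxy could be sized on a core whose values all lie clear of the limit.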